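A few compounds are considered here, and "the series" means these few. Any claim that something is new, unique, unknown or untested is made for them only; others in the source may bear on it.

The study concerns a set of compounds built on a shared core and examined in an assay on isolated protein for binding affinity to adenosine receptor A3 (Homo sapiens); a lower number here means a stronger inhibitor, a higher number a weaker inhibitor. Compound 1 `CNC(=O)[C@]12C[C@@H]1[C@@H](n1cnc3c(N[C@H]4C[C@@H]4c4ccc(F)c(F)c4)nc(C#Cc4cccc(F)c4)nc31)[C@H](O)[C@@H]2O` gives in this assay only a limit, >= 99 nM. Compound 2 `CNC(=O)[C@]12C[C@@H]1[C@@H](n1cnc3c(NCc4cccc(Cl)c4)nc(C#Cc4ccc(Cl)s4)nc31)[C@H](O)[C@@H]2O` also reaches only a limit in this assay, >= 99 nM. Compound 3 `CCOC(=O)[C@]12C[C@@H]1[C@@H](n1ccc3c(NCCCc4ccc(OC)c(O)c4)nc(C#Cc4ccc(Cl)s4)nc31)[C@H](O)[C@@H]2O` stands at a limit as well in this assay, >= 99 nM. All three values sit at the limit of >= 99 nM in this assay, at which 3 of the 3 values shown sit, so none of the measured compounds shows a resolved inhibition constant, and compound 3 cannot be set apart from the other two on the numbers shown.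

Compound 4 `CCOC(=O)[C@]12C[C@@H]1[C@@H](n1ccc3c(NCCCc4ccc(OC)c(O)c4)nc(C#Cc4ccccc4)nc31)[C@H](O)[C@@H]2O` has not yet been measured in this assay. It differs from compound 3 in one place (phenyl in place of 5-chlorothiophen-2-yl on a triple-bonded carbon). Going by the values given here, no step between two measured compounds is available to gauge such a change, and the three limits give no direction for it. Compound 4 is therefore expected to stay at the limit too, with the step that the limit leaves unreadable from compound 3 to compound 4 estimated as none beyond the scatter. The inhibition constant of compound 4 in this assay is estimated at 250 nM, with a range from 60 nM to 3000 nM, and most likely reported again only as a limit.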

Compound 4, inhibition constant: >= 99 nM
Compound 4 ended at the assay's limit; the forecaster's own chance of this, stated with the estimate: 70%; the middle value does not contradict the limit.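

Compound 3 and compound 4 both end as limits in this assay, so no step can be read for phenyl in place of 5-chlorothiophen-2-yl on a triple-bonded carbon: the limit of >= 99 nM in this assay, at which 4 of the 4 values shown sit.

The compounds shown leave open what inhibition constant any of them actually has in this assay, and whether this exchange changes it at all.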